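The source may hold more compounds than are shown below. What is called first, only, known or untested is meant among the compounds shown, and "the series" means these compounds.

Measured so far:
- Compound 1 `COc1cc(Cl)cc(-c2nn(-c3cccc(NC(=O)c4ccc(Cl)c(Cl)c4)c3)cc2-c2ccncc2)c1`: 58.4%
- Compound 2 `COc1cc(Cl)cc(-c2nn(-c3cccc(NC(=O)Nc4ccc(Cl)c(Cl)c4)c3)cc2-c2ccncc2)c1`: 1.93%

Among the measured compounds shown here, in a functional assay on OVCAR-8 cells (Homo sapiens) for inhibition, read by sulforhodamine B assay, with a stated time of 48 h, tested at 10 uM (a higher number here means a weaker effect of the compound at the concentration tested, a lower number a stronger effect), compound 2 holds the lowest number of the two, the only other value being that of compound 1; the single measured step is a number 56.5 percentage points lower from compound 1 to compound 2 (beyond the scatter). Compound 3 `COc1cc(Cl)cc(-c2nn(-c3cccc(NC(=O)Nc4cccc(C(F)(F)F)c4)c3)cc2-c2ccncc2)c1` differs from compound 2 in one place: 3-(trifluoromethyl)phenyl in place of 3,4-dichlorophenyl on an amide-type nitrogen. For the measured compounds named here, the step from compound 1 to compound 2 changed the group on the carbonyl carbon, not the aryl on the amide-type nitrogen, so it does not bear directly on this change; no measured step covers it. The step of a number 8.1 percentage points higher from compound 2 to compound 3 (within the scatter) is therefore expected to stay within the scatter, and compound 3 is estimated at 10%, with a range from 0% to 50%.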

Compound 3, a percentage reported as activity, at one concentration (the size of the read-out at that concentration, not a potency): -12.3%
For compound 3 the middle estimate is 22.3 percentage points above the measured one, and the stated range ends above it.
By their numbers in this assay, from the lowest: compound 3; then compound 2; then compound 1.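

In this assay, the group on the amide-type nitrogen also moves the read-out: 3-(trifluoromethyl)phenyl in place of 3,4-dichlorophenyl gives a number 14.2 percentage points lower from compound 2 to compound 3 (beyond the scatter). This position therefore still matters once the (aryl)amino group stands on the carbonyl carbon. Set against the aryl directly on the carbonyl carbon, (3-(trifluoromethyl)phenyl)amino gives a number 70.7 percentage points lower from compound 1 to compound 3 (beyond the scatter), and nothing at hand explains either step.

Going by these compounds, whether a single chlorine, a nitrile or a methoxy group on this phenyl ring would follow compound 3 remains open. The same holds for a cyclohexyl group or a longer alkyl chain in place of the aryl.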